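Carbamate-protected long-chain acid compared with its aminomethyl analogue

The compounds below may be only part of what the source reports. "The series", "measured", "known", "first", "only" and "open" are said of these compounds alone.

Compound 1 `CCCCCCCCCCCCCCC(NC(=O)OC(C)(C)C)C(=O)O` stands at the low end of the two numbers recorded in an ADME assay on cells (Splenocyte, Mus musculus, strain BALB/c) for cytotoxicity, read by MTT assay, tested at 10 ug/mL; on this read-out higher numbers stand for a stronger effect at the one concentration tested and lower numbers for a weaker effect: compound 1 gives 5.1%, while compound 2 `CCCCCCCCCCCCCCC(N)CO` gives 20.2%, a gap beyond the scatter. Among the measured compounds shown here, no direct step has been measured toward compound 3 `CCCCCCCCCCCCCCC(CN)NC(=O)OC(C)(C)C`, which differs from compound 1 by aminomethyl in place of carboxy on a saturated chain carbon bound to an amide-type nitrogen and a saturated chain carbon. Compound 3 is expected to show a modest upward step of a number 6.9 percentage points higher from compound 1 to compound 3 (within the scatter), not far beyond the scatter. For compound 3 the estimate is 12%, within a range from 2% to 30%.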

Compound 3, a percentage reported as activity, at one concentration (the size of the read-out at that concentration, not a potency): 4.3%
The estimate for compound 3 lay 7.7 percentage points above the measured number; low and high end bracket the measured number.
By their numbers in this assay, from the lowest: compounds 3 and 1 (each within the scatter of the next); then compound 2.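

In this assay, aminomethyl in place of carboxy on a saturated chain carbon bound to an amide-type nitrogen and a saturated chain carbon gives a number 0.8 percentage points lower from compound 1 to compound 3 (within the scatter). Among the compounds shown here, this is the first step measured at this position, and it shows that exchanging these two groups there leaves the read-out within the scatter. No evidence bears on the reason for this result. The compounds shown leave open whether a hydroxymethyl group or a primary amide at this position, or a longer chain, would give a different reading.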